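A few compounds are considered here, and "the series" means these few. Any claim that something is new, unique, unknown or untested is made for them only; others in the source may bear on it.

Compound 1 `CC(=O)Nc1cccc(-c2ccc(C(=O)N(Cc3cccc(OCCCCCC(=O)O)c3)C(C)C)cc2)c1` — in an ADME assay on BJ cells (Homo sapiens) for cytotoxicity, read by CellTiter-Glo and resazurin assay, with a stated time of 72 h (on this read-out lower numbers stand for an effect already at smaller amounts and higher numbers for an effect only at larger amounts of compound), compound 1 gives > 26000 nM, which is a limit of the assay and not a number.
Compound 2 `CC(C)N(Cc1cccc(OCCCCCC(=O)O)c1)C(=O)c1ccc(-c2ccoc2)cc1` — in this assay compound 2 gives > 26000 nM, again only a limit.

Compound 1 therefore stands at the limit that both measured values share, (the limit of > 26000 nM in this assay, at which 2 of the 2 values shown sit). The step that the two limits leave unreadable from compound 1 to compound 2 cannot be read, since both of its ends are limits. Compound 3 `CCOC(=O)CCCCCOc1cccc(CN(C(=O)c2ccc(-c3cccc(NC(C)=O)c3)cc2)C(C)C)c1` differs from compound 1 by ethyl in place of hydrogen on an oxygen next to a carbonyl group. Among the measured compounds shown here, no measured step touches that position, so the only guide is compound 1 at its limit. Compound 3 is expected to stay beyond the measured range as well, a step that the limit leaves unreadable from compound 1 to compound 3, with an estimated value of 30000 nM, between 10000 nM and 100000 nM.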

Compound 3, half-maximal effective concentration: > 26000 nM
Compound 3: a limit, no number (the forecaster's own chance of this, stated with the estimate: 80%); the middle value lies beyond the limit too.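

No step can be read from compound 1 to compound 3, since both ends are limits and not numbers: the limit of > 26000 nM in this assay, at which 3 of the 3 values shown sit. What stays open is whether the ethyl or furan-3-yl changes alter the effect in this assay at all, and at what amount any of these compounds acts.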